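The compounds below may be only part of what the source reports. "The series", "measured", "known", "first", "only" and "open" are said of these compounds alone.

In an ADME assay on PBMC cells (Homo sapiens) for cytotoxicity, read by trypan blue exclusion, with a stated time of 6 days (a lower number here means that less compound is tolerated, a higher number that more compound is tolerated), three close relatives of compound 4 have already been examined, all built on one shared core. Compound 1, `C[C@@]1(O)[C@H](O)[C@@H](CO)O[C@H]1n1cnc2c(N)nc(N=[N+]=[N-])nc21`, gives > 100000 nM, which is a limit of the assay rather than a number. Compound 2, `C[C@@]1(O)[C@H](O)[C@@H](CO)O[C@H]1n1cnc2c(N)nc(O)nc21`, likewise reaches only a limit, > 100000 nM. Compound 3, `C[C@@]1(O)[C@H](O)[C@@H](CO)O[C@H]1n1cnc2c(N)nc(F)nc21`, also stops at a limit, > 100000 nM. The three steps among them, a step that the two limits leave unreadable from compound 1 to compound 2, a step that the two limits leave unreadable from compound 1 to compound 3 and a step that the two limits leave unreadable from compound 2 to compound 3, therefore carry no readable size: where compound 3 stands can be stated only as a limit, and the limit of > 100000 nM in this assay, at which 3 of the 3 values shown sit, is the whole of the evidence at hand. Compound 4, `CONc1nc(N)c2ncn([C@@H]3O[C@H](CO)[C@@H](O)[C@@]3(C)O)c2n1`, differs from compound 3 by methoxyamino in place of fluoro on an aromatic carbon. For the measured compounds named here, none of the measured steps covers this particular exchange, and none of them has a size, so no direction can be drawn from them; what can be said is only that every measured exchange on that aromatic carbon left the read-out at its limit. The expectation is that compound 4 behaves in the same way, with a step that the limit leaves unreadable from compound 3 to compound 4 that is not beyond the scatter. Compound 4 is thus estimated at 150000 nM, within 60000 nM to 400000 nM, and most likely again reported only as a limit.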

Compound 4, half-maximal cytotoxic concentration: > 100000 nM
Compound 4 ended at the assay's limit; the forecaster's own chance of this, stated with the estimate: 85%; the middle value lies beyond the limit too.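

Compound 4 sits at a limit of this assay, as do compound 1, compound 2 and compound 3, so no step to compound 4 can be read: the limit of > 100000 nM in this assay, at which 4 of the 4 values shown sit.

The compounds shown leave open the half-maximal cytotoxic concentration of all four, and whether the exchanges on that aromatic carbon change it at all.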